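Carbamate on the ring hydroxyl of compound 2

The compounds below may be only part of what the source reports. "The series", "measured", "known", "first", "only" and "open" are said of these compounds alone.

Measured so far in a functional assay on PANC-1 cells (Homo sapiens) for inhibition, read by MTT assay, with a stated time of 24 h, tested at 10 uM; a lower number here means less inhibition, a higher number more inhibition at the concentration tested (going by the name of the read-out):
- compound 1, `CC(C)=CCC1Cc2c(O)cc(=O)n(CCCO)c2CC1(C)C`: 0%
- compound 2, `CC(C)=CCC/C(C)=C/CC1Cc2c(O)cc(=O)n(CCCO)c2CC1(C)C`: 0%
- compound 3, `CC(C)=CCC1Cc2c(OCCCNS(=O)(=O)c3ccc(C(F)(F)F)cc3)cc(=O)n(CCCO)c2CC1(C)C`: 0%

Compound 2 stands level with compound 1 and compound 3 at the digits reported; all three sit at the bottom of the scale. Among the compounds with values here, the one step between measured neighbours, no change at the digits printed from compound 1 to compound 2 (within the scatter), changes the side chain on the saturated ring and moves nothing. Within the data shown here, compound 3 carries a substituted chain on the ring oxygen that compound 1 leaves as hydroxy, and its value shows the same flat result; no step is computed for that pair.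

Compound 4, `CC(C)=CCC/C(C)=C/CC1Cc2c(OC(=O)Nc3ccc(F)cc3F)cc(=O)n(CCCO)c2CC1(C)C`, differs from compound 2 by (2,4-difluorophenyl)carbamoyl in place of hydrogen on an oxygen on an aromatic ring, hydroxy going to ((2,4-difluorophenyl)carbamoyl)oxy. Among the measured compounds shown here, no measured step touches a carbamoyl on this oxygen, so the only guide is that every compound so far, whatever sits on that oxygen, reads at the floor. Against that background no step beyond the scatter is expected: a number 3 percentage points higher from compound 2 to compound 4 (within the scatter) is the estimate for the move from compound 2. For compound 4 the expected read-out in this assay is 3%, in the range -5% to 15%.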

Compound 4, a percentage reported as inhibition, at one concentration (the size of the read-out at that concentration, not a potency): 15.6%
The estimate for compound 4 lay 12.6 percentage points below the measured number; measured number above the stated range.
By their numbers in this assay, from the lowest: compounds 1, 2 and 3 (each within the scatter of the next); then compound 4.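

In this assay, within the data shown here, the step to the carbamate, a number 15.6 percentage points higher from compound 2 to compound 4 (beyond the scatter), is the first to leave the scatter, whereas the side chain change, no change at the digits printed from compound 1 to compound 2 (within the scatter), moved nothing. This marks the oxygen on the aromatic ring as a place where a change can register in this read-out, though compound 4 at 15.6% still shows only modest inhibition at the single concentration tested. No supporting data bear on the origin of this step.

The compounds shown leave open whether the step belongs to the carbamoyl link or to the 2,4-difluorophenyl group, which a plain phenylcarbamoyl or an acetyl group on the same oxygen would help separate. They also leave open whether (2,4-difluorophenyl)carbamoyl gives a similar step on the shorter side chain of compound 1.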